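Swapping a Trifluoromethoxy for a Trifluoromethyl Group

A few compounds are considered here, and "the series" means these few. Any claim that something is new, unique, unknown or untested is made for them only; others in the source may bear on it.

Measured so far:
- compound 1, `O=C(Nc1cccnc1)c1ccc(Cl)cc1`: 88%
- compound 2, `O=C(Nc1cccnc1)c1ccc(OC(F)(F)F)cc1`: 3%

In an assay on V79 cells for inhibition of cytochrome P450 11B2, mitochondrial (Homo sapiens), tested at 500 nM (on this read-out lower numbers stand for less inhibition and higher numbers for more inhibition at the one concentration tested (going by the name of the read-out)), compound 1 gives 88%, while compound 2 gives 3%, the lowest of the two numbers measured. Going by the values given here, the only measured step, a number 85 percentage points lower from compound 1 to compound 2 (beyond the scatter), shows that exchanging the group on this aromatic carbon can move the read-out across almost its whole span.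

Compound 3, `O=C(Nc1cccnc1)c1ccc(C(F)(F)F)cc1`, has not yet been measured. It differs from compound 2 by trifluoromethyl in place of trifluoromethoxy on an aromatic carbon. Among the compounds with values here, no measured pair shows this exact exchange, so the step from compound 1 to compound 2 is the only guide: it tells that the group at this position matters greatly, but not where trifluoromethyl will fall between the two measured values.

Given that, compound 3 is expected to land somewhere in the middle, a step of a number 42 percentage points higher from compound 2 to compound 3 (beyond the scatter) upward from compound 2, with a wide range. The estimate for compound 3 is 45%, between 10% and 85%.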

Compound 3, a percentage reported as inhibition, at one concentration (the size of the read-out at that concentration, not a potency): 1%
Beside the measured number, compound 3's estimate is 44 percentage points above it, outside the stated range (below it).
By their numbers in this assay, from the lowest: compounds 3 and 2 (each within the scatter of the next); then compound 1.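

In this assay, losing the oxygen of trifluoromethoxy makes no readable difference, with a number 2 percentage points lower from compound 2 to compound 3 (within the scatter) at this position on the aromatic ring. Chloro now stands apart from both fluorine-bearing groups, since a number 87 percentage points lower from compound 1 to compound 3 (beyond the scatter) is about as large as the drop already seen with trifluoromethoxy, so the low read-out is not tied to trifluoromethoxy alone. Nothing available explains why the two groups match or why chloro differs.

Still open, going by these compounds, is whether chloro is an unusual case at this position, or whether groups such as bromo, methyl or an amine would keep the high read-out of compound 1. A single concentration also leaves open how much potency separates these compounds, and whether compound 2 and compound 3 would still match at higher concentrations.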